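Alkyne substituent truncation in the diethylaminoethyl amide series

This account rests on a few compounds, and the source may have more. Where it says the series, first, only, none or still open, it means among the compounds named here.

Compound 1 `CCN(CC)CCNC(=O)C1CC(C(CC)(CC)c2ccc(C#CC(C)(C)O)c(C)c2)=CN1CC` gives 56.3% in an assay on isolated protein for binding affinity to vitamin D3 receptor (Homo sapiens), read by fluorescence polarization, tested at 1 uM; on this read-out higher numbers stand for more inhibition at the one concentration tested (going by the name of the read-out) and lower numbers for less inhibition. Compound 2 `CCCC(O)(C#Cc1ccc(C(CC)(CC)C2=CN(CC)C(C(=O)NCCN(CC)CC)C2)cc1C)CCC` gives 51.1%, and compound 3 `CCN(CC)CCNC(=O)C1CC=C(C(CC)(CC)c2ccc(C#CC(O)C3CCCC3)c(C)c2)N1CC` gives 47.9%; the value of compound 2 lies within the scatter of both compound 1 and compound 3. The step of a number 5.2 percentage points lower from compound 1 to compound 2 (within the scatter) shows that enlarging the group on the triple-bonded carbon leaves the read-out essentially where it was. Compound 4 `C#Cc1ccc(C(CC)(CC)C2=CN(CC)C(C(=O)NCCN(CC)CC)C2)cc1C` removes that group entirely: a hydrogen atom in place of a group of 8 heavy atoms (7 carbon, 1 oxygen; no ring), on a triple-bonded carbon. Among the measured compounds shown here, no measured step covers loss of the whole group, so the expectation rests on the indifference seen across compounds 1, 2 and 3, with added uncertainty. A step of a number 9.1 percentage points lower from compound 2 to compound 4 (within the scatter) is expected, a small drop at most. The estimate for compound 4 is 42%, with a range from 20% to 60%.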

Compound 4, a percentage reported as inhibition, at one concentration (the size of the read-out at that concentration, not a potency): "not active" (no number reported)
Compound 4: no number reported; there is nothing to compare the estimate with.
By their numbers in this assay, from the lowest: compounds 3, 2 and 1 (each within the scatter of the next).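

Among the compounds shown here, compound 4 carries no number in this assay, so no step from compound 2 to compound 4 can be read. Nothing shown bears on the reason for this result. The compounds shown leave open how a group smaller than that of compound 1 on the triple-bonded carbon would read.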